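An Acid in Place of an Acetamide

A few compounds are considered here, and "the series" means these few. Any claim that something is new, unique, unknown or untested is made for them only; others in the source may bear on it.

Compound 2 `CC(=O)Nc1ccc(-c2nnc(C3(c4ccc(Cl)cc4)CCC3)n2C)c(Cl)c1` stands at the top of the two numbers gathered so far. In a functional assay on the whole organism (strain ICR) for inhibition, with Mus musculus as the target, read by scintillation counting, with a stated time of 16 h, at a dose of 10 mg/kg by the oral route (on this read-out lower numbers stand for less inhibition and higher numbers for more inhibition at the one dose given (going by the name of the read-out)), compound 2 gives 27%, while compound 1 `Cn1c(-c2ccc(-c3cncnc3)cc2)nnc1C1(c2ccc(Cl)cc2)CCC1` gives -4%, a gap that lies beyond the scatter of repeated measurements. Going by the values given here, no step between measured compounds is available to guide the next move, which replaces a single group: carboxy in place of acetamido on an aromatic carbon. Compound 3 `Cn1c(-c2ccc(C(=O)O)cc2Cl)nnc1C1(c2ccc(Cl)cc2)CCC1` carries this carboxy group and still awaits its number. Among the compounds with values here, with no comparable step to lean on, the change is expected to cost a little inhibition, though the expected shift, a number 15 percentage points lower from compound 2 to compound 3 (beyond the scatter), is small enough that it may sit within the usual scatter. Compound 3 is therefore expected to give about 12%, most likely falling between -20% and 40%.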

Compound 3, a percentage reported as inhibition, in the whole organism at one dose (the size of the read-out at that dose, not a potency): 38%
Beside the measured number, compound 3's estimate is 26 percentage points below it; the measured number falls inside the stated range.
By their numbers in this assay, from the lowest: compound 1; then compound 2; then compound 3.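

In this assay, carboxy in place of acetamido on an aromatic carbon gives a number 11 percentage points higher from compound 2 to compound 3 (beyond the scatter), a modest step. The position, meta to a chloro group and para to a large group, therefore keeps its inhibition at the one dose given when the nitrogen-bearing acetamido group leaves and an all-oxygen carboxy group enters, something compound 2 alone could not show. Nothing available gives a measured reason for this step.

From the compounds shown here alone, what stays open is whether the carboxy group is special here, or whether an amine or a methyl ester on the same aromatic carbon would read the same. Going by these compounds, it is also open how much the chloro group contributes to the level seen with the carboxy group in place.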